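Replacing the naphthalenyl sulfonyl group with a pyridinyl-thiophenyl one

The source may hold more compounds than are shown below. What is called first, only, known or untested is meant among the compounds shown, and "the series" means these compounds.

Measured so far:
Compound 1: `COc1cc2c(cc1N1C[C@@H](C)N(C)[C@@H](C)C1)N(S(=O)(=O)c1cccc(Br)c1)CC2` — 0.7
Compound 2: `COc1cc2c(cc1N1C[C@@H](C)N[C@@H](C)C1)N(S(=O)(=O)c1ccc3ccccc3c1)CC2` — 1
Compound 3: `COc1cc2c(cc1N1C[C@@H](C)N[C@@H](C)C1)N(S(=O)(=O)c1ccc(-c3ccccn3)cc1)CC2` — 1.1

Three compounds sharing one core have been examined in a functional assay with growth hormone secretagogue receptor type 1 (Homo sapiens) as the target; a lower number here means a smaller maximal response, a higher number a larger maximal response. Compound 2 gives 1 in this assay. Compound 3 gives 1.1, a number that lies within the scatter of compound 2, so the two cannot be told apart on intrinsic activity. Compound 1 gives 0.7, which sits beyond the scatter below compound 2, so compound 2 stands clearly above compound 1 and level with compound 3.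

The next compound, compound 4, is `COc1cc2c(cc1N1C[C@@H](C)N[C@@H](C)C1)N(S(=O)(=O)c1ccc(-c3ccccn3)s1)CC2`. It keeps the core, the methoxy group and the unsubstituted dimethylpiperazine of compound 2, and differs only at the aryl sulfonyl position: 5-(pyridin-2-yl)thiophen-2-yl in place of naphthalen-2-yl on a sulfonyl sulfur

Among the measured compounds shown here, no single-change step between measured compounds exists in this set, so the size of this change has to be judged from the spread of the three values. Both compounds 2 and 3, which carry a bicyclic or a biaryl group on the sulfonyl sulfur, sit close to a full response. Compound 4 carries a biaryl group of the same kind, and the step from compound 2 to compound 4 is therefore expected to be no change at the digits printed from compound 2 to compound 4 (within the scatter), that is, no change beyond the scatter. Compound 4 is expected to give 1 in this assay, with a likely range from 0.8 to 1.2.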

Compound 4, intrinsic activity: the largest response reached, as a fraction of the reference agonist's: 0.9
Beside the measured number, compound 4's estimate is 0.10 above it; the range from low to high includes it.
By their numbers in this assay, from the lowest: compound 1; then compounds 4, 2 and 3 (each within the scatter of the next, the first and the last beyond it).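

In this assay, among the compounds shown here, the step from naphthalen-2-yl to 5-(pyridin-2-yl)thiophen-2-yl on a sulfonyl sulfur gives a number 0.10 lower from compound 2 to compound 4 (within the scatter), and it is the only step in the set that isolates this position with everything else held constant. It shows that the maximal response stays within the scatter when two six-membered aromatic rings of carbon only give way to one five-membered aromatic ring with 1 hetero atom and one six-membered aromatic ring with 1 hetero atom, a change that takes the hydrogen-bond acceptors on this group from 0 to 2. Nothing available explains why the response holds across this exchange.

The compounds shown leave open whether a much smaller group on the sulfonyl sulfur, such as methyl, or a phenyl ring bearing a carboxylic acid, would keep the same maximal response. They also leave open how far the lower value of compound 1, 0.7, belongs to its 3-bromophenyl group or to the methyl on its piperazine nitrogen, since it differs from the other compounds in both places.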